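Removing the Bromine from the Aryl Ketone of Compound 1

This account rests on a few compounds, and the source may have more. Where it says the series, first, only, none or still open, it means among the compounds named here.

Of the compounds shown here, three built on one shared core have been tested in a functional assay on A549 cells (Homo sapiens) for cytotoxicity, read by MTT assay, with a stated time of 48 h; on this read-out lower numbers stand for stronger inhibition and higher numbers for weaker inhibition. Compound 1 (`COc1cc(-c2nnc3n2NC(c2ccco2)C(C(=O)c2ccc(Br)cc2)S3)cc(OC)c1OC`) gives 42100 nM. Compound 2 (`COc1cc(-c2nnc3n2NC(c2cccs2)C(C(=O)c2ccc(F)cc2)S3)cc(OC)c1OC`) gives 45000 nM, and the two numbers sit within the usual scatter of each other. Compound 3 (`COc1cc(C(=O)C2Sc3nnc(-c4cc(OC)c(OC)c(OC)c4)n3NC2c2cccs2)cc(OC)c1OC`) reaches only a limit of the assay, > 100000 nM, rather than a number. Among the compounds with values here, the one measured step in this set is an at least 2.2-fold higher number from compound 2 to compound 3 (0.34 log units; beyond the scatter), a change on the ring bound to the carbonyl.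

Compound 4 (`COc1cc(-c2nnc3n2NC(c2ccco2)C(C(=O)c2ccccc2)S3)cc(OC)c1OC`) differs from compound 1 by hydrogen in place of bromo on an aromatic carbon. Within the data shown here, no measured step removes a halogen from this ring, so the step from compound 2 to compound 3 bears on it only loosely, as a much larger change at the same carbonyl-bound ring. Compound 1 and compound 2 differ in two places, one being the halogen on this ring, and their numbers fall within the scatter of each other, which hints that the halogen matters little here. The expected step in this assay from compound 1 is therefore a 1.3-fold higher number from compound 1 to compound 4 (0.12 log units; within the scatter), close to the scatter and, if anything, toward a weaker result. Compound 4 is estimated at 55000 nM, with a range from 25000 nM to 120000 nM.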

Compound 4, half-maximal inhibitory concentration: 33400 nM
For compound 4 the middle estimate is 1.6-fold (0.22 log units) above the measured one, within the range that was stated.
By their numbers in this assay, from the lowest: compounds 4, 1 and 2 (each within the scatter of the next). At a limit, above all of these: compound 3.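

In this assay, taking the bromo group off the ring bound to the carbonyl gives a 1.3-fold lower number from compound 1 to compound 4 (0.10 log units; within the scatter). Within the data shown here, this is the first reading of this position with everything else in the molecule held the same, since the earlier comparison of compound 1 with compound 2 mixed the halogen with a second difference; it shows directly that, on this core, 4-bromophenyl and phenyl cannot be told apart in this test. Compound 3 remains at a limit of the assay, so the much larger change on the same ring can't be sized in the way this step can, and it still stands apart from the other three compounds: the limit of > 100000 nM in this assay, at which 1 of the 4 values shown sits.

On these data alone, with only bromo and hydrogen compared directly at this position, it remains open whether an amine or a carboxylic acid there would move the number beyond the scatter. Among these compounds, it also remains open whether removing the halogen would give a similarly small step with the other groups on the shared core, such as the one carried by compound 2.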